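The source may report more compounds than this note shows. Statements on the series, on what has been measured and on what is new or still open speak of the compounds shown alone.

Measured compounds:
compound 1, `COc1ccc(-c2ccc3c(c2)C(=O)C(=O)N3C)cc1`, in a functional assay on HepG2 cells (Homo sapiens) for antiproliferative activity, read by MTT assay, with a stated time of 48 h; a lower number here means a stronger inhibitor, a higher number a weaker inhibitor: 6670 nM
compound 2, `COc1ccc(CN2C(=O)C(=O)c3cc(-c4ccc(F)c(Cl)c4)ccc32)cc1`, in this assay: > 10000 nM

Compound 2 stands at a limit of this assay: its result > 10000 nM is the limit and not a number, the point at which one of the two values shown sits (the limit of > 10000 nM in this assay, at which 1 of the 2 values shown sits). Compound 1 gives a number, 6670 nM, in this assay. Among the compounds with values here, compound 1 and compound 2 differ in more than one place, so the two values show only that compound 1 returns a number where compound 2 returns the limit.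

Compound 3, `COc1ccc(CN2C(=O)C(=O)c3cc(-c4ccc(O)cc4)ccc32)cc1`, is not yet measured. It differs from compound 2 by 4-hydroxyphenyl in place of 3-chloro-4-fluorophenyl on an aromatic carbon. Within the data shown here, no step between measured compounds bears on this change, and compound 2 gives only a limit, so the size of the step cannot be read from the data. The step is expected to be a step that the limit leaves unreadable from compound 2 to compound 3, which is within the usual scatter and carries a fair chance of ending at the limit again. Compound 3 is estimated at 12000 nM in this assay, with a range from 4000 nM to 40000 nM.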

Compound 3, half-maximal inhibitory concentration: > 10000 nM
Compound 3: no number, only a limit; the forecaster's own chance of this, stated with the estimate: 55%; the middle value lies beyond the limit too.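

In this assay compound 3 gives > 10000 nM as a limit and not a number. Compound 2 also stands at a limit, so no step between compound 2 and compound 3 can be read: the limit of > 10000 nM in this assay, at which 2 of the 3 values shown sit.

Going by these compounds, whether 4-hydroxyphenyl and 3-chloro-4-fluorophenyl on the shared core differ in this assay at all stays open.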